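Loss of one chloro on the shared core

The source may report more compounds than this note shows. Statements on the series, on what has been measured and on what is new or still open speak of the compounds shown alone.

Two members of the series have numbers in a functional assay on SK-OV-3 cells (Homo sapiens) for cytotoxicity, read by sulforhodamine B assay, with a stated time of 48 h; on this read-out higher numbers stand for weaker inhibition of growth and lower numbers for stronger inhibition of growth. Compound 1 `ClCc1ccc(Cn2cnc3c(Cl)ncnc32)cc1` gives 13800 nM. Compound 2 `ClCc1ccccc1Cn1cnc2c(Cl)nc(Cl)nc21` gives 3540 nM; this is the lower of the two numbers, and its gap to compound 1 lies beyond the scatter. Compound 3 `ClCc1ccccc1Cn1cnc2c(Cl)ncnc21` has not yet been run in this assay. It differs from compound 2 in one place: hydrogen in place of chloro on an aromatic carbon, in words, hydrogen in place of chloro on an aromatic carbon. Among the measured compounds shown here, no pair of measured compounds carries exactly this change, so the size of the step is open. Compound 3 shares its core with compound 1 and the rest of its structure with compound 2, and the two measured numbers pull in different directions. The working assumption is a modest weakening from compound 2, probably not far past the scatter. Compound 3 is therefore expected at 6500 nM, with a range from 2200 nM to 19000 nM. The expected step of a 1.8-fold higher number from compound 2 to compound 3 (0.26 log units; within the scatter) is a small move toward weaker inhibition of growth.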

Compound 3, concentration for total growth inhibition: 15900 nM
Estimate against measurement, compound 3: 2.4-fold (0.39 log units) below, and the stated range covers the measured number.
By their numbers in this assay, from the lowest: compound 2; then compounds 1 and 3 (each within the scatter of the next).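

In this assay the chloro on the aromatic carbon between two ring nitrogen atoms now has a measured single-place change, and replacing it with hydrogen gives a 4.5-fold higher number from compound 2 to compound 3 (0.65 log units; beyond the scatter), a move toward weaker inhibition of growth. This position therefore affects the read-out on the side of the structure that carries compound 2 and compound 3, and with the chloro gone, compound 3 at 15900 nM lies within the scatter of compound 1 at 13800 nM, so the lowest number among the three belongs only to the compound that keeps this chloro. This rests on a single pair, and no measurement in hand bears on why the step has this size.

Only chloro and hydrogen are shown on this carbon, so what an amine, a methoxy group or a fluoro there would give remains open. Whether the step carries over to the structure of compound 1 is also open, since no partner of compound 1 with a chloro on this carbon is among the compounds shown.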